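From 4-fluorophenyl to tert-butyl on an aromatic nitrogen

This account rests on a few compounds, and the source may have more. Where it says the series, first, only, none or still open, it means among the compounds named here.

Compound 1 `O=C(O)c1cn(-c2ccc(F)cc2)c2nc(N3CCC(N4CCCCC4)CC3)c([N+](=O)[O-])cc2c1=O` reads > 126000 nM in an ADME assay on Vero cells (Chlorocebus sabaeus) for cytotoxicity, read by MTT assay, with a stated time of 72 h (on this read-out higher numbers stand for weaker inhibition and lower numbers for stronger inhibition), and this is a limit of the assay. For the measured compounds named here, compound 2 `O=C(O)c1cn(-c2ccc(F)cc2)c2nc(N3CCC(n4c(=O)[nH]c5cc(Cl)ccc54)CC3)c([N+](=O)[O-])cc2c1=O` gives 53900 nM, the only actual number so far in this assay. Going by the values given here, the one measured step, an at least 2.3-fold lower number from compound 1 to compound 2 (0.36 log units; beyond the scatter), exchanged a group on a saturated ring carbon. Compound 3 `CC(C)(C)n1cc(C(=O)O)c(=O)c2cc([N+](=O)[O-])c(N3CCC(n4c(=O)[nH]c5cc(Cl)ccc54)CC3)nc21` keeps that group of compound 2 and instead carries tert-butyl in place of 4-fluorophenyl on an aromatic nitrogen. The measured step therefore lies at another place and gives no direct size for this change, so compound 2 remains the only anchor. No shift beyond the scatter is expected in this assay, and the expected change is a 1.2-fold higher number from compound 2 to compound 3 (0.08 log units; within the scatter). For compound 3 the estimated value is 65000 nM, with an expected range of 25000 nM to 125000 nM.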

Compound 3, half-maximal inhibitory concentration: 57700 nM
Compound 3: middle estimate off by 1.1-fold (0.05 log units), on the high side, and the stated range covers the measured number.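

In this assay, the aromatic nitrogen now has a measured step of its own, where the earlier step lay on a saturated ring carbon: tert-butyl in place of 4-fluorophenyl gives a 1.1-fold higher number from compound 2 to compound 3 (0.03 log units; within the scatter). With the group shared by compound 2 and compound 3 on the saturated ring carbon, a group with no ring and a six-membered aromatic ring of carbon only therefore read alike at this position on this cytotoxicity read-out. Nothing in the data offers a reason for this flat step.

Going by these compounds, whether the two groups also read alike when the saturated ring carbon carries the group of compound 1 remains open. So does the reading with an ethyl or cyclopropyl group on the aromatic nitrogen, or with a chain ending in an amine or a carboxylic acid.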